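The source may hold more compounds than are shown below. What is called first, only, known or untested is meant among the compounds shown, and "the series" means these compounds.

Measured compounds:
compound 1, `CC1=C(C(C)C(=O)N(C)CCN(C)C)c2cc(F)ccc2/C1=C\c1ccc([S+](C)[O-])cc1`: 11900 nM
compound 2, `CC1=C(C(C)C(=O)NCCN2CCCCC2)c2cc(F)ccc2/C1=C\c1ccc([S+](C)[O-])cc1`: 9670 nM

Among the measured compounds shown here, in a functional assay on HT-29 cells (Homo sapiens) for inhibition, read by CellTiter-Glo, with a stated time of 72 h (on this read-out lower numbers stand for higher toxicity in this test and higher numbers for lower toxicity in this test), compound 2 gives the lowest of the two numbers, and the single measured step, a 1.2-fold lower number from compound 1 to compound 2 (0.09 log units; within the scatter), stays within the scatter. Compound 3, `CC1=C(C(C)C(=O)NCCN2CCNCC2)c2cc(F)ccc2/C1=C\c1ccc([S+](C)[O-])cc1`, differs from compound 2 by piperazin-1-yl in place of piperidin-1-yl on a saturated chain carbon, two bonds along the chain from an amide-type nitrogen. For the measured compounds named here, no measured step tests this particular change; the one step available, a 1.2-fold lower number from compound 1 to compound 2 (0.09 log units; within the scatter), altered the same amine-bearing chain without a shift beyond the scatter. For compound 3 the expected change is therefore a 1.0-fold higher number from compound 2 to compound 3 (0.01 log units; within the scatter), none beyond the scatter. The estimate for compound 3 is 10000 nM, with a range from 4000 nM to 25000 nM.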

Compound 3, half-maximal cytotoxic concentration: > 50000 nM
Compound 3: a limit, no number (the forecaster's own chance of this, stated with the estimate: 10%); middle value at least 5.0-fold (0.69 log units) away from the limit.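

In this assay compound 3 gives > 50000 nM, which is a limit of the assay and not a number. Piperazin-1-yl in place of piperidin-1-yl gives an at least 5.1-fold higher number from compound 2 to compound 3 (0.71 log units; beyond the scatter), and the full change of amine gives an at least 4.2-fold higher number from compound 1 to compound 3 (0.62 log units; beyond the scatter). So the amine at this place can move the read-out towards lower toxicity in this test, which the earlier step, a 1.2-fold lower number from compound 1 to compound 2 (0.09 log units; within the scatter), did not show.

Still open, on these data alone, is whether the second ring nitrogen alone or the hydrogen on it matters: morpholin-4-yl or 4-methylpiperazin-1-yl at this place would separate the two.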